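The source may hold more compounds than are shown below. What is called first, only, known or untested is meant among the compounds shown, and "the series" means these compounds.

Measured compounds in this series:
compound 1 `Cc1cc(NC(=O)Nc2ccc([N+](=O)[O-])c(C(F)(F)F)c2)c2ccccc2n1` — > 25000 nM in an ADME assay on Raji cells (Homo sapiens) for cytotoxicity, with a stated time of 72 h (a lower number here means that less compound is needed, a higher number that more compound is needed for the effect), a limit of the assay
compound 2 `Cc1cc(NC(=O)Nc2ccccc2C(F)(F)F)c2ccccc2n1` — > 25000 nM, likewise a limit
compound 3 `COC(=O)c1cccc(NC(=O)Nc2cc(C)nc3ccccc23)c1` — 26000 nM, the one number in the set

All three share a urea-linked core and differ only in the substituents of the second aryl ring. Compound 1 gives > 25000 nM in this assay, which is a limit and not a measured number. Compound 2 gives > 25000 nM, also a limit. Compound 3 gives 26000 nM, the only actual number shown, and it lies close to the limit of > 25000 nM in this assay, at which 2 of the 3 values shown sit, rather than apart from it; with no step between measured compounds available, there is nothing in the set that shows how any substituent change moves the read-out.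

Compound 4 `Cc1cc(NC(=O)Nc2cccc(N(C)C)c2)c2ccccc2n1` is the untested member and differs from compound 3 in one place: dimethylamino in place of methoxycarbonyl on an aromatic carbon. Compound 3 gives 26000 nM. The other two members sit at a limit of the assay. No basis exists for expecting a step beyond the scatter in either direction; the read-out is expected to stay in the weak region.

Compound 4 is therefore expected at 30000 nM, with a range of 10000 nM to 100000 nM. The expected step of a 1.2-fold higher number from compound 3 to compound 4 (0.06 log units; within the scatter) is essentially none, and a limit rather than a number is a real possibility.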

Compound 4, half-maximal effective concentration: > 25000 nM
Compound 4: only a limit was reported; the forecaster's own chance of this, stated with the estimate: 55%; the middle value does not contradict the limit.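

In this assay compound 4 gives > 25000 nM, a limit and not a number. The step between compound 3 and compound 4 cannot be read, and compound 4 joins the other limit values: the limit of > 25000 nM in this assay, at which 3 of the 4 values shown sit.

The compounds shown leave open whether any substituent change on the shared core moves this read-out, and by how much.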